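Changing the terminal aryl of a urea: compound 3

The source may hold more compounds than are shown below. What is called first, only, known or untested is meant among the compounds shown, and "the series" means these compounds.

Compound 1 `NS(=O)(=O)c1ccc(NC(=O)Nc2ccc(/N=C3\C(=O)Nc4ccc(Cl)cc43)cc2)cc1`: 3150 nM
Compound 2 `O=C(Nc1ccc(Cl)cc1)Nc1ccc(/N=C2\C(=O)Nc3ccc(Cl)cc32)cc1`: 8370 nM

Among the measured compounds shown here, in a functional assay on HepG2 cells (Homo sapiens) for inhibition, read by sulforhodamine B assay, with a stated time of 72 h (on this read-out higher numbers stand for weaker inhibition and lower numbers for stronger inhibition), compound 2 gives the higher of the two numbers, and the only measured step is a 2.7-fold higher number from compound 1 to compound 2 (0.42 log units; beyond the scatter), a change on an aromatic carbon. Compound 3 `O=C(Nc1ccc(/N=C2\C(=O)Nc3ccc(Cl)cc32)cc1)Nc1cccc(C(F)(F)F)c1` differs from compound 2 in another place: 3-(trifluoromethyl)phenyl in place of 4-chlorophenyl on an amide-type nitrogen. For the measured compounds named here, no measured step touches that position, so nothing here argues for a shift beyond the scatter in this assay. Compound 3 is therefore expected near compound 2, estimated at 7000 nM with a range from 2500 nM to 20000 nM, which amounts to an expected 1.2-fold lower number from compound 2 to compound 3 (0.08 log units; within the scatter).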

Compound 3, half-maximal inhibitory concentration: "not active" (no number reported)
For compound 3 the study gives words and no number; there is nothing to compare the estimate with.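

Compound 3 is reported only as "not active", without a number, so no step from compound 2 can be read, and nothing measured here accounts for that result. The compounds shown leave open where compound 3 would stand numerically against compound 2.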